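Series notes: chloro to trifluoromethyl swap, compound 3 estimate

A few compounds are considered here, and "the series" means these few. Any claim that something is new, unique, unknown or untested is made for them only; others in the source may bear on it.

Measured compounds:
compound 1 `OB(c1ccc(C(F)(F)F)cc1)c1ccc(C(F)(F)F)cc1` — 11200 nM
compound 2 `OB(c1ccccc1)c1ccc(Cl)cc1` — 12000 nM

In an assay on HEK293 cells for inhibition of transient receptor potential cation channel subfamily V member 6 (Homo sapiens), read by FLIPR, with a stated time of 5 min (a higher number here means a weaker inhibitor, a lower number a stronger inhibitor), compound 1 gives 11200 nM, and in the same assay compound 2 gives 12000 nM. Compound 2 holds the higher of the two numbers, but its gap to compound 1 lies within the scatter, so the two read as equal.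

Compound 3 `OB(c1ccccc1)c1ccc(C(F)(F)F)cc1` is not yet measured. Relative to compound 2 the change is trifluoromethyl in place of chloro on an aromatic carbon. Going by the values given here, no step between measured compounds covers this swap. Compound 1 carries two trifluoromethyl groups and compound 2 one chloro, and their numbers agree, which gives no sign that the swap moves the read-out.

For compound 3 the step of a 1.1-fold lower number from compound 2 to compound 3 (0.04 log units; within the scatter) is expected to stay within the scatter, with no firm direction. Compound 3 is therefore estimated at 11000 nM, with a range from 5000 nM to 25000 nM.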

Compound 3, half-maximal inhibitory concentration: 12500 nM
Beside the measured number, compound 3's estimate is 1.1-fold (0.06 log units) below it; the range from low to high includes it.
By their numbers in this assay, from the lowest: compounds 1, 2 and 3 (each within the scatter of the next).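

In this assay the swap now has a direct reading: trifluoromethyl in place of chloro on the aromatic carbon gives a 1.0-fold higher number from compound 2 to compound 3 (0.02 log units; within the scatter), so the two groups read as equal at this position. Hydrogen in place of trifluoromethyl on an aromatic carbon gives a 1.1-fold higher number from compound 1 to compound 3 (0.05 log units; within the scatter), so the second trifluoromethyl of compound 1 shows no effect on the read-out either. No data accompany these numbers that could account for this flat picture.

On these data alone, only hydrogen, chloro and trifluoromethyl appear at these aromatic carbons, and all three compounds read alike, so it remains open whether this position can move the read-out at all. An amine or a carboxylic acid on the same aromatic carbon would test that question.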